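This account rests on a few compounds, and the source may have more. Where it says the series, first, only, none or still open, it means among the compounds named here.

Compound 1, `COc1cccc2sc(NC(=O)c3ccc(C(F)(F)F)cc3)nc12`: > 10 ug/mL
Compound 2, `COc1ccc(C(=O)Nc2nc3cc(C)cc(C)c3s2)cc1`: > 10 ug/mL

In a functional assay on SK-HEP1 cells (Homo sapiens) for antiproliferative activity, read by sulforhodamine B assay (on this read-out lower numbers stand for stronger inhibition of growth and higher numbers for weaker inhibition of growth), compound 1 gives > 10 ug/mL, which is a limit of the assay and not a number. In this assay compound 2 gives > 10 ug/mL, also a limit. Compound 1 thus stands at the limit of > 10 ug/mL in this assay, at which 2 of the 2 values shown sit, and nothing separates the two measured compounds. Compound 3, `COc1ccc(C(=O)Nc2nc3c(OC)cccc3s2)cc1`, is not yet measured; it differs from compound 1 by methoxy in place of trifluoromethyl on an aromatic carbon. For the measured compounds named here, no measured step covers this change, and compound 2, which carries the same methoxy group, sits at the limit as well. For compound 3 the step that the limit leaves unreadable from compound 1 to compound 3 is expected to be small, without a clear direction. Compound 3 is therefore estimated at 15 ug/mL, between 5 ug/mL and 50 ug/mL.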

Compound 3, concentration for 50% growth inhibition: 2.11 ug/mL
The estimate for compound 3 lay 7.1-fold (0.85 log units) above the measured number; measured number outside the range, below it.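

In this assay, methoxy in place of trifluoromethyl on an aromatic carbon, para to a large group, gives an at least 4.7-fold lower number from compound 1 to compound 3 (0.67 log units; beyond the scatter). For the compounds shown here, this is the first sign that the group at this place matters, since this single change moves growth inhibition beyond the scatter. The true size of the step stays unknown, because it starts from a limit and not a number: the limit of > 10 ug/mL in this assay, at which 2 of the 3 values shown sit.

Going by these compounds, it remains open whether the gain comes from adding methoxy or from losing trifluoromethyl. An amine, a hydroxyl group or a longer chain such as ethoxy at this place could separate the two.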